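Bromophenyl for Tert-Butyl at the Cytotoxicity Limit

This account rests on a few compounds, and the source may have more. Where it says the series, first, only, none or still open, it means among the compounds named here.

Compound 1 `COc1nc(C2CCOCC2)ccc1[C@@H](c1ccccc1)[C@@](O)(CCN(C)C)c1cccc2ccccc12`: 22.5 ug/mL
Compound 2 `COc1nc(-c2ccc(Cl)cc2)ccc1[C@@H](c1ccccc1)[C@@](O)(CCN(C)C)c1cccc2ccccc12`: > 64 ug/mL
Compound 3 `COc1nc(C(C)(C)C)ccc1[C@@H](c1ccccc1)[C@@](O)(CCN(C)C)c1cccc2ccccc12`: > 64 ug/mL

In a toxicity assay on HeLa cells (Homo sapiens) for cytotoxicity (a lower number here means that less compound is tolerated, a higher number that more compound is tolerated), compound 1 gives a number, 22.5 ug/mL. Compound 2 reaches only the limit of this assay, > 64 ug/mL. Compound 3 likewise sits at the limit, > 64 ug/mL, so its place is known only as a bound (the limit of > 64 ug/mL in this assay, at which 2 of the 3 values shown sit). The step of an at least 2.8-fold higher number from compound 1 to compound 3 (0.45 log units; beyond the scatter) is readable, while a step that the two limits leave unreadable from compound 2 to compound 3 is not.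

Compound 4 `COc1nc(-c2ccc(Br)cc2)ccc1[C@@H](c1ccccc1)[C@@](O)(CCN(C)C)c1cccc2ccccc12` differs from compound 3 by 4-bromophenyl in place of tert-butyl on an aromatic carbon. The step that bears on it is an at least 2.8-fold higher number from compound 1 to compound 2 (0.45 log units; beyond the scatter), where a 4-chlorophenyl group also carried the value to the limit. Compound 4 is therefore expected to stay at the limit, and a step that the limit leaves unreadable from compound 3 to compound 4 is estimated as no step beyond the scatter. The estimate for compound 4 is 90 ug/mL, between 45 ug/mL and 180 ug/mL.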

Compound 4, half-maximal cytotoxic concentration: > 64 ug/mL
Compound 4 was reported as a limit (the forecaster's own chance of this, stated with the estimate: 80%); the middle value is on the limit's open side.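

In this assay compound 4 gives > 64 ug/mL as a limit, so 4-bromophenyl in this place joins 4-chlorophenyl and tert-butyl at that limit. Putting 4-bromophenyl in place of oxan-4-yl gives an at least 2.8-fold higher number from compound 1 to compound 4 (0.45 log units; beyond the scatter) and leaves compound 1 the only one of the four with a number. The steps among compound 2, compound 3 and compound 4 cannot be read, because all three sit at the same limit: the limit of > 64 ug/mL in this assay, at which 3 of the 4 values shown sit.

The compounds shown leave open whether an amine or a morpholine in this place would give a number as oxan-4-yl does. They also leave open how far compound 2, compound 3 and compound 4 lie beyond the limit.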